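The source may report more compounds than this note shows. Statements on the series, on what has been measured and on what is new or still open speak of the compounds shown alone.

Measured so far:
compound 1 `COc1cc(C)cc(-c2c(-c3ccnc(-c4ccc(C(C)=O)cc4)c3)cnn2CC#N)c1` — 100%
compound 2 `COc1cc(C)cc(-c2nn(CC#N)cc2-c2ccc(-c3cccc(C(C)=O)c3)nc2)c1` — 99%
compound 3 `Cc1cc(O)cc(-c2nn(CC#N)cc2-c2ccnc(-c3ccc(Oc4ccccc4)cc3)c2)c1` — 91%

In a functional assay on KM12 cells (Homo sapiens) for cytotoxicity, read by sulforhodamine B assay, with a stated time of 48 h, tested at 0.001 uM (on this read-out higher numbers stand for a weaker effect at the one concentration tested and lower numbers for a stronger effect), compound 1 gives 100%, the highest of the three numbers, yet compound 2 at 99% and compound 3 at 91% both sit within the scatter of it, so no order among the three can be read. All three numbers show little effect at the concentration used.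

Compound 4 `COc1cc(C)cc(-c2c(-c3ccnc(-c4ccc(N(C)C)cc4)c3)cnn2CC#N)c1` differs from compound 1 in one place:
dimethylamino in place of acetyl on an aromatic carbon
Going by the values given here, no step between measured compounds is available for this change. The step of a number 2 percentage points lower from compound 1 to compound 4 (within the scatter) is expected to stay inside the scatter, because compound 1 already gives 100% and the series shows nothing that moves the read-out. Compound 4 is therefore expected at 98%, in the range 88% to 105%.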

Compound 4, a percentage reported as activity, at one concentration (the size of the read-out at that concentration, not a potency): 95%
Compound 4: the middle estimate sits 3 percentage points above what was measured, within the range that was stated.
By their numbers in this assay, from the lowest: compounds 3, 4, 2 and 1 (each within the scatter of the next).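

In this assay dimethylamino in place of acetyl gives a number 5 percentage points lower from compound 1 to compound 4 (within the scatter) and so adds a second substituent at this place, on an aromatic carbon para to a large group, without a step beyond the scatter. At the one concentration tested, the 4-acetylphenyl and 4-(dimethylamino)phenyl compounds cannot be told apart. No measurement shown bears on this result.

As far as these compounds go, whether a carboxylic acid or a longer chain at this place would move the read-out beyond the scatter stays open. The compounds shown also leave open how the 4-acetylphenyl and 4-(dimethylamino)phenyl compounds compare at any other concentration.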